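Selenium for sulfur on the bis-acyl isothiourea core

The source may hold more compounds than are shown below. What is called first, only, known or untested is meant among the compounds shown, and "the series" means these compounds.

Compound 2 `CS/C(=N\C(=O)c1ccno1)NC(=O)c1ccno1` is measured in a functional assay on HepG2 cells (Homo sapiens) for cytotoxicity, read by MTT assay, with a stated time of 72 h; on this read-out lower numbers stand for stronger inhibition of growth and higher numbers for weaker inhibition of growth. Compound 2 gives only a limit in this assay, > 100000 nM. Compound 1 `CS/C(=N\C(=O)c1sccc1Cl)NC(=O)c1sccc1Cl` likewise gives only a limit in this assay, > 100000 nM. Compound 3 `C[Se]/C(=N\C(=O)c1cccs1)NC(=O)c1cccs1` gives a number in this assay, 1500 nM. Two of the three values shown sit at the limit of > 100000 nM in this assay, at which 2 of the 3 values shown sit; compound 2 is one of them, so the numbers place it at the limit, not beyond it. Compound 4 `C[Se]/C(=N\C(=O)c1ccno1)NC(=O)c1ccno1` has not been measured; it differs from compound 2 by a group of 2 heavy atoms (1 carbon, 1 selenium; no ring) in place of a group of 2 heavy atoms (1 carbon, 1 sulfur; no ring), on a carbon with a double bond to nitrogen. No measured step covers this change; compound 3 carries the selenium group and is the only compound shown with a number, so a step toward stronger inhibition is expected, but not a large one. Compound 4 is expected at 15000 nM, within 2000 nM to 100000 nM, an expected step of an at least 6.6-fold lower number from compound 2 to compound 4 (0.82 log units; beyond the scatter).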

Compound 4, concentration for total growth inhibition: 9350 nM
Beside the measured number, compound 4's estimate is 1.6-fold (0.21 log units) above it, within the range that was stated.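

In this assay, replacing methylsulfanyl with the selenium group (1 carbon, 1 selenium) on a carbon with a double bond to nitrogen now has a direct reading, an at least 10-fold lower number from compound 2 to compound 4 (1.02 log units; beyond the scatter). On this core, the selenium compound gives a number where the sulfur compound does not. That step has only a floor, as compound 2 is a limit of the assay: the limit of > 100000 nM in this assay, at which 2 of the 4 values shown sit.

From the compounds shown here alone, compound 3 has no sulfur partner here, so whether the change carries over to other acyl groups stays open. Also open, going by these compounds, is what a longer chain on selenium or an amine in this place would give.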